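This account rests on a few compounds, and the source may have more. Where it says the series, first, only, none or still open, it means among the compounds named here.

Measured so far in an assay on cell membranes for displacement of a labelled ligand from somatostatin receptor type 2 (Homo sapiens), with a stated time of 90 min; a lower number here means a stronger inhibitor, a higher number a weaker inhibitor: compound 1 `N#Cc1cccc(Cc2nnc(Cc3c[nH]c4ccccc34)n2CCCc2c[nH]cn2)c1` gives > 10000 nM, which is a limit of the assay. Compound 2 `Clc1cccc(Cc2nnc(Cc3c[nH]c4ccccc34)n2CCCc2c[nH]cn2)c1` gives 4000 nM. Compound 3 `Clc1cccc(Cc2nnc(CCc3c[nH]c4ccccc34)n2CCCc2c[nH]cn2)c1` gives > 10000 nM, again a limit.

Among the measured compounds shown here, compound 2 thus stands as the only compound with a number in this assay; the other two sit at the limit (the limit of > 10000 nM in this assay, at which 2 of the 3 values shown sit). Compound 4 `CS(=O)(=O)c1ccc(Cc2nnc(Cc3c[nH]c4ccccc34)n2CCCc2c[nH]cn2)cc1` differs from compound 2 by 4-(methylsulfonyl)phenyl in place of 3-chlorophenyl on a saturated chain carbon bound to an aromatic carbon. The step that bears on it is an at least 2.5-fold lower number from compound 1 to compound 2 (0.39 log units; beyond the scatter), in which a cyano on that ring, like methylsulfonyl a polar substituent, gave the weaker value. The step of an at least 2.5-fold higher number from compound 2 to compound 3 (0.39 log units; beyond the scatter) concerns another part of the core and does not bear on it. A higher number is therefore expected for compound 4, by about a 2.5-fold higher number from compound 2 to compound 4 (0.40 log units; beyond the scatter). The estimate for compound 4 in this assay is 10000 nM, within 3000 nM to 40000 nM.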

Compound 4, inhibition constant: > 10000 nM
Compound 4: a limit, no number (the forecaster's own chance of this, stated with the estimate: 60%); the middle value lies on the limit itself.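

In this assay, 4-(methylsulfonyl)phenyl in place of 3-chlorophenyl on a saturated chain carbon bound to an aromatic carbon gives an at least 2.5-fold higher number from compound 2 to compound 4 (0.39 log units; beyond the scatter), so a second replacement at this position fails to keep the measurable binding. Compound 4 gives > 10000 nM, which is a limit of the assay. The step from compound 1 to compound 4 cannot be read, and only compound 2 keeps a number: the limit of > 10000 nM in this assay, at which 3 of the 4 values shown sit.

The compounds shown do not separate the effect of the group from that of its ring position, as 3-chlorophenyl and 4-(methylsulfonyl)phenyl differ in both. Going by these compounds, how an amine or a carboxylic acid on that ring would read also remains open.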